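Compound 4: a Fluorophenylcarbonyl Placed Directly on the Oxygen

The source may report more compounds than this note shows. Statements on the series, on what has been measured and on what is new or still open speak of the compounds shown alone.

Of the compounds shown here, three sharing one core have been measured in a functional assay on HEK293 cells for agonist activity at G-protein coupled receptor 39 (Homo sapiens), read by scintillation proximity assay and inositol phosphate accumulation, with a stated time of 75 min, in the presence of a further agent that is not named here; a higher number here means that more compound is needed for the effect, a lower number that less compound is needed. Compound 1 `Cc1nn(-c2ncnc3nc[nH]c23)c2c1C(OCC(=O)c1ccc(F)cc1)CC(=O)N2` gives 3 nM, compound 2 `Cc1noc(C)c1COC1CC(=O)Nc2c1c(C)nn2-c1ncnc2nc[nH]c12` gives 5 nM, and compound 3 `Cc1nn(-c2ncnc3nc[nH]c23)c2c1C(C(=O)N(C)c1nccs1)CC(=O)N2` gives 18 nM. On these numbers compound 2 stands second highest of the three: its nearest neighbour is compound 1, and the step of a 1.7-fold higher number from compound 1 to compound 2 (0.22 log units; within the scatter) lies within the scatter, while the step of a 3.6-fold higher number from compound 2 to compound 3 (0.56 log units; beyond the scatter) lies beyond it, though only modestly.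

Compound 4 `Cc1nn(-c2ncnc3nc[nH]c23)c2c1C(OC(=O)c1ccc(F)cc1)CC(=O)N2` has not yet been measured. It differs from compound 2 in one place: (4-fluorophenyl)carbonyl in place of (3,5-dimethyl-1,2-oxazol-4-yl)methyl on an oxygen on a saturated carbon. The same difference, cut one bond further out, reads (3,5-dimethyl-1,2-oxazol-4-yl)methoxy to ((4-fluorophenyl)carbonyl)oxy, so compound 4 carries the (4-fluorophenyl)carbonyl of compound 1 but with no saturated chain carbon between it and the oxygen.

Among the compounds with values here, the step that bears most on this change is the one between compound 1 and compound 2, which stayed within the scatter even though the group on the oxygen changed entirely. The move from compound 2 to compound 3, which changed the link at the saturated ring carbon itself, cost more. Compound 4 keeps the oxygen on the saturated ring carbon, so the step of a 1.2-fold higher number from compound 2 to compound 4 (0.08 log units; within the scatter) is expected to remain small. For compound 4 the expected value in this assay is 6 nM, within 1.5 nM to 25 nM.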

Compound 4, half-maximal effective concentration: 4 nM
Compound 4: middle estimate off by 1.5-fold (0.18 log units), on the high side; the range from low to high includes it.
By their numbers in this assay, from the lowest: compounds 1, 4 and 2 (each within the scatter of the next); then compound 3.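

In this assay, the oxygen on the saturated ring carbon carries the (4-fluorophenyl)carbonyl directly with no shift beyond the scatter: removing the saturated chain carbon gives the step of a 1.3-fold higher number from compound 1 to compound 4 (0.12 log units; within the scatter), so the presence of that chain carbon makes no readable difference here. The step of a 1.3-fold lower number from compound 2 to compound 4 (0.10 log units; within the scatter) adds a second case within the scatter, with a six-membered aromatic ring of carbon only entering and a five-membered aromatic ring with 2 hetero atoms leaving, so compounds 1, 2 and 4 do not separate on the group on the oxygen, while the step of a 4.5-fold lower number from compound 3 to compound 4 (0.65 log units; beyond the scatter) lies beyond the scatter, though modestly, when the change is made at the saturated ring carbon itself. Nothing measured alongside these numbers accounts for them.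

The compounds shown leave open whether any group on this oxygen would move the number beyond the scatter, such as a plain methyl or a longer chain ending in an amine or a carboxylic acid. They also leave open what the fluorine contributes, as every (4-fluorophenyl)carbonyl compound here carries it and a plain phenyl ketone or benzoate does not appear.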